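Notes on compounds 1 to 3: a bicyclic replacement

The source may hold more compounds than are shown below. What is called first, only, known or untested is meant among the compounds shown, and "the series" means these compounds.

Measured so far:
compound 1 `O=C(Nc1ccc(-n2ncc3c(Br)cccc32)cc1)Nc1ccc(Cl)c(C(F)(F)F)c1` gives 16600 nM in a functional assay on SGC-7901 cells (Homo sapiens) for cytotoxicity, read by MTT assay, with a stated time of 72 h; on this read-out higher numbers stand for weaker inhibition and lower numbers for stronger inhibition
compound 2 `Cc1cccc2c1cnn2-c1ccc(NC(=O)Nc2ccc(Cl)c(C(F)(F)F)c2)cc1` gives 14200 nM in this assay

Compound 2 stands lowest of the two numbers, but its step of a 1.2-fold lower number from compound 1 to compound 2 (0.07 log units; within the scatter) is within the scatter, so no order between the two is claimed. Compound 3 `O=C(Nc1ccc(-n2ncc3ccncc32)cc1)Nc1ccc(Cl)c(C(F)(F)F)c1` differs from compound 2 by a group of 9 heavy atoms (6 carbon, 3 nitrogen; one five-membered aromatic ring with 2 hetero atoms, one six-membered aromatic ring with 1 hetero atom) in place of a group of 10 heavy atoms (8 carbon, 2 nitrogen; one five-membered aromatic ring with 2 hetero atoms, one six-membered aromatic ring of carbon only), on an aromatic carbon. Going by the values given here, no measured step bears on this change; the single step from compound 1 to compound 2 concerns only the methyl in place of bromo and is within the scatter. The expected step is therefore none beyond the scatter, a 1.0-fold lower number from compound 2 to compound 3 (0.01 log units; within the scatter). Compound 3 is estimated at 14000 nM, with a range from 5000 nM to 40000 nM.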

Compound 3, half-maximal inhibitory concentration: > 32000 nM
Compound 3 gave a limit, no number (the forecaster's own chance of this, stated with the estimate: 5%); at least 2.2-fold (0.35 log units) between middle value and limit.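

Compound 3 yields a limit of the assay and not a number: the limit of > 32000 nM in this assay, at which 1 of the 3 values shown sits.

Unlike the exchange of methyl and bromo, replacing the 4-methyl-1H-indazol-1-yl group with a group carrying a hetero atom in its six-membered ring gives a step beyond the scatter, with an at least 2.2-fold higher number from compound 2 to compound 3 (0.35 log units; beyond the scatter). Against the bromo compound the reading is weaker, with an at least 1.9-fold higher number from compound 1 to compound 3 (0.28 log units; that floor lies within the scatter), so this pair sets no order.

As far as these compounds go, the full size of the step remains open, as does whether the ring nitrogen or the loss of the methyl carries it. Also open, from the compounds shown here alone, is where an amine or a methoxy group on the six-membered ring would fall.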